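The source may report more compounds than this note shows. Statements on the series, on what has been measured and on what is new or still open speak of the compounds shown alone.

Measured compounds:
compound 1 `CC(C(=O)N1CCN(c2ccccc2)CC1)N1C(=O)CCC1=O` — 0%
compound 2 `CCC(C(=O)N1CCN(c2ccc(C(F)(F)F)cc2)CC1)N1C(=O)CCC1=O` — 0%
compound 3 `CC(C(=O)N1CCN(c2ccccc2C(F)(F)F)CC1)N1C(=O)CCC1=O` — 75%

In a functional assay on the whole organism (strain Swiss) with Mus musculus as the target, in the maximal electroshock model, with a stated time of 2 h, at a dose of 300 mg/kg by the intraperitoneal route (a higher number here means a stronger effect of the compound at the dose given, a lower number a weaker effect), compound 1 gives 0%. It stands level with compound 2 at the digits shown, and the two together are the lowest of the three numbers; the furthest number from compound 1 belongs to compound 3, which gives 75%. Within the data shown here, the only step measured from compound 1 is the one to compound 3, a number 75 percentage points higher from compound 1 to compound 3 (beyond the scatter), a change of trifluoromethyl in place of hydrogen on an aromatic carbon.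

Compound 4 `Cc1cccc(N2CCN(C(=O)C(C)N3C(=O)CCC3=O)CC2)c1` is not yet measured. Its difference from compound 1 is methyl in place of hydrogen on an aromatic carbon. Among the measured compounds shown here, only the step from compound 1 to compound 3 bears on it, and only loosely: the entering group there was trifluoromethyl, here it is methyl, and the place on the ring is not the same. Compound 2, which also carries a trifluoromethyl on the ring, gives a number no different from compound 1, so a group on the ring does not by itself bring the large rise seen in compound 3. A modest rise is therefore expected for compound 4, a number 20 percentage points higher from compound 1 to compound 4 (beyond the scatter), with wide uncertainty. The expected value for compound 4 is 20%, within 0% to 60%.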

Compound 4, a percentage reported as activity, at one dose (the size of the read-out at that dose, not a potency): 0%
For compound 4 the middle estimate is 20 percentage points above the measured one, within the range that was stated.
By their numbers in this assay, from the lowest: compounds 1, 2 and 4 (each within the scatter of the next); then compound 3.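

In this assay the methyl group, placed on an aromatic carbon meta to a large group, gives no change at the digits printed from compound 1 to compound 4 (within the scatter) and so leaves the read-out at the level of the unsubstituted phenyl compound. The earlier compounds shown here showed only that trifluoromethyl could give a large step, a number 75 percentage points higher from compound 1 to compound 3 (beyond the scatter), and that a trifluoromethyl on the ring of compound 2 could come with no activity at this dose; compound 4 adds that the change from phenyl to 3-methylphenyl, one added carbon at this place, is not enough on its own to bring any measurable effect at this dose. No measurement is available that would explain why this methyl group leaves the number unmoved.

The compounds shown leave open whether the effect seen with compound 3 belongs to trifluoromethyl itself or to its place on the ring, since neither methyl at that place nor trifluoromethyl at the place of the methyl in compound 4 appears among them. They also leave open what a chlorine atom, a methoxy group or an amine would do at either place on the ring.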